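A Hydroxy for a Nitro at the Assay Limit

This account rests on a few compounds, and the source may have more. Where it says the series, first, only, none or still open, it means among the compounds named here.

Of the compounds shown here, three sharing one core have been tested in a functional assay on G-361 cells (Homo sapiens) for antiproliferative activity (a lower number here means a stronger inhibitor, a higher number a weaker inhibitor), and only one gave a number. Compound 1 (`Nc1n[nH]c(N)c1/N=N/c1cccc2c1CCCC2`) gives 77000 nM as its half-maximal inhibitory concentration. Compound 2 (`Nc1n[nH]c(N)c1/N=N/c1cccc([N+](=O)[O-])c1`) stands at > 100000 nM which is a limit of the assay and not a number. Compound 3 (`Nc1n[nH]c(N)c1/N=N/c1ccccc1O`) reports > 100000 nM which is likewise a limit. Compound 4 (`Nc1n[nH]c(N)c1/N=N/c1cccc(O)c1`) carries hydroxy in place of nitro on an aromatic carbon relative to compound 2. With the limit of > 100000 nM in this assay, at which 2 of the 3 values shown sit, as the main evidence, a small step toward stronger inhibition is expected in this assay and perhaps none beyond the scatter. The expected step is an at least 1.1-fold lower number from compound 2 to compound 4 (0.04 log units; that floor lies within the scatter) on this estimate. Compound 4 is estimated at 90000 nM with an expected range from 40000 nM to 200000 nM as its span.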

Compound 4, half-maximal inhibitory concentration: > 100000 nM
Compound 4: no number, only a limit (the forecaster's own chance of this, stated with the estimate: 55%); middle value at least 1.1-fold (0.04 log units) away from the limit.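

Compound 2 and compound 4 each give only a limit of the assay, not a number, and the step between them cannot be read. The compounds shown leave open whether hydroxy in place of nitro changes the inhibition at all.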